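Anilide series: halogen swap on the amide-type nitrogen

The source may hold more compounds than are shown below. What is called first, only, known or untested is meant among the compounds shown, and "the series" means these compounds.

Three compounds of the series have numbers, all from an assay on isolated protein (Mus musculus) for inhibition of IL15-IL15 receptor (Homo sapiens), read by resazurin assay, with stated times of 30 min and 2.5 days; a higher number here means a weaker inhibitor, a lower number a stronger inhibitor. Compound 1 `CCCOc1ccc(NC(=O)CSc2nnc(Cc3nn(C)c(=O)c4ccccc34)n2C)cc1` gives only a limit of that assay, > 30000 nM, and no number. Compound 2 `Cn1c(Cc2nn(C)c(=O)c3ccccc23)nnc1SCCCCCCCC(=O)Nc1ccc(Cl)cc1Cl` gives 1900 nM in this assay. Compound 3 `Cn1c(Cc2nn(C)c(=O)c3ccccc23)nnc1SCCCCCCCCCCC(=O)Nc1ccc(Cl)cc1Cl` gives 3300 nM in this assay. Of the two numbers shown, compound 2 holds the lower one, but the gap to compound 3 is within the usual scatter of repeated measurements, so no order between compound 2 and compound 3 is claimed; both differ from compound 2 in more than one place from compound 1, so no single step is read from them.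

Compound 4 `Cn1c(Cc2nn(C)c(=O)c3ccccc23)nnc1SCCCCCCCC(=O)Nc1ccc(F)cc1F` is not yet measured. It differs from compound 2 in one place: 2,4-difluorophenyl in place of 2,4-dichlorophenyl on an amide-type nitrogen. Among the measured compounds shown here, no measured pair covers this kind of change, so there is no direct precedent for its size. The working expectation in this assay is a modest step toward a higher number, small enough that it may fall within the scatter of compound 2, and a larger weakening is not excluded.

On that basis compound 4 is expected to give about 4000 nM in this assay, with a range from 1500 nM to 12000 nM, which corresponds to an expected step of a 2.1-fold higher number from compound 2 to compound 4 (0.32 log units; beyond the scatter).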

Compound 4, half-maximal inhibitory concentration: 2300 nM
Estimate against measurement, compound 4: 1.7-fold (0.24 log units) above; low and high end bracket the measured number.
By their numbers in this assay, from the lowest: compounds 2, 4 and 3 (each within the scatter of the next). At a limit, above all of these: compound 1.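

In this assay, among the compounds shown here, 2,4-difluorophenyl in place of 2,4-dichlorophenyl on an amide-type nitrogen gives a 1.2-fold higher number from compound 2 to compound 4 (0.08 log units; within the scatter), so at this position the exchange of chlorine for fluorine on the ring produces no step that can be told from repeated measurement. For the compounds shown here, the earlier compounds gave no reading at a single place, and this pair is the first to isolate one change, though it holds only on the chain carried by compound 2 and compound 4. Nothing measured here gives a cause for a step of this size.

As far as these compounds go, it remains open whether the ring substituents matter at all at this position: an unsubstituted phenyl, a 2,4-dimethoxyphenyl or a pyridyl group on the same amide-type nitrogen would test a wider change than this exchange of one halogen for another. Also open, from the compounds shown here alone, is whether 2,4-difluorophenyl reads the same on the longer chain of compound 3, and how an amine or a carboxylic acid in place of the anilide at the end of the chain would read in this assay.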